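The source may report more compounds than this note shows. Statements on the series, on what has been measured and on what is new or still open speak of the compounds shown alone.

Compound 1 `COc1ncnc2c1c(-c1ccsc1)cn2[C@@H]1O[C@H](CO)[C@@H](O)[C@H]1O` carries a thiophen-3-yl group on the shared core, and in a functional assay on K562 cells (Homo sapiens), read by MTT assay, with a stated time of 72 h (a lower number here means a stronger inhibitor, a higher number a weaker inhibitor), compound 1 gives 3450 nM. Compound 2 `COc1nc(N)nc2c1c(-c1ccsc1)cn2[C@@H]1O[C@H](CO)[C@@H](O)[C@H]1O` adds an amino group, the change being (amino in place of hydrogen on an aromatic carbon). For compound 2 the result is only a limit of the assay, > 20000 nM. The step is therefore an at least 5.7-fold higher number from compound 1 to compound 2 (0.76 log units; beyond the scatter), with the value sitting at the limit of > 20000 nM in this assay, at which 1 of the 3 values shown sits. Compound 3 `COc1ncnc2c1c(-c1cccs1)cn2[C@@H]1O[C@H](CO)[C@@H](O)[C@H]1O` instead changes the core by thiophen-2-yl in place of thiophen-3-yl on an aromatic carbon; in this assay compound 3 gives 6200 nM, a step of a 1.8-fold higher number from compound 1 to compound 3 (0.25 log units; within the scatter). Compound 4 `COc1nc(N)nc2c1c(-c1cccs1)cn2[C@@H]1O[C@H](CO)[C@@H](O)[C@H]1O` is not yet measured and differs from compound 3 by amino in place of hydrogen on an aromatic carbon, the same change that led from compound 1 to compound 2. Resting on that earlier step, an at least 5.7-fold higher number from compound 1 to compound 2 (0.76 log units; beyond the scatter), a step of about a 5.6-fold higher number from compound 3 to compound 4 (0.75 log units; beyond the scatter) is expected. Compound 4 is thus estimated at 35000 nM, between 12000 nM and 100000 nM.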

Compound 4, half-maximal inhibitory concentration: > 20000 nM
Compound 4 was reported as a limit (the forecaster's own chance of this, stated with the estimate: 70%); the middle value is on the limit's open side.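

In this assay, compound 4 is reported only as a limit, > 20000 nM. Amino in place of hydrogen on an aromatic carbon gives an at least 3.2-fold higher number from compound 3 to compound 4 (0.50 log units; beyond the scatter), so the number rises on both cores, and the two steps stand side by side as follows: the same change on two cores in this assay, an at least 5.7-fold higher number (0.76 log units; beyond the scatter) from compound 1 to compound 2 and an at least 3.2-fold higher number (0.50 log units; beyond the scatter) from compound 3 to compound 4; the limit leaves it open whether they differ. This shows the direction carrying over but not its size, and the step between compound 2 and compound 4 cannot be read, since both rest on the same limit: the limit of > 20000 nM in this assay, at which 2 of the 4 values shown sit.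

As far as these compounds go, whether the thiophene attachment matters once the amino group is present stays open. So does whether a different group on that same aromatic carbon, such as methyl or dimethylamino, would also raise the number.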